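Phenyl for methyl on the ring nitrogen of compound 2

This account rests on a few compounds, and the source may have more. Where it says the series, first, only, none or still open, it means among the compounds named here.

Of the compounds shown here, two have been measured in a functional assay, with a stated time of 60 min, tested at 0.1 mM; a lower number here means a weaker effect, a higher number a stronger effect of the compound at the concentration tested. Compound 1 `COC(=O)c1c(O)c2ccccc2n(-c2ccccc2)c1=O` gives 9.1% in this assay, and compound 2 `Cn1c(=O)c(C(=O)NCCN)c(O)c2ccccc21` gives 11.5%. Compound 2 thus stands with the higher of the two numbers, but the gap to compound 1 lies within the scatter, so the two cannot be told apart on the activity shown. Compound 3 `NCCNC(=O)c1c(O)c2ccccc2n(-c2ccccc2)c1=O` has not yet been measured. It differs from compound 2 in one respect: phenyl in place of methyl on an aromatic nitrogen. For the measured compounds named here, no step between measured compounds is available for this change; compound 1, which carries a phenyl on its aromatic nitrogen, shows only 9.1%, which gives no sign that the phenyl raises the activity. For compound 3 a step of a number 1.5 percentage points lower from compound 2 to compound 3 (within the scatter) is expected, that is none beyond the scatter. Compound 3 is therefore estimated at 10%, with a range from 0% to 25%.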

Compound 3, a percentage reported as activity, at one concentration (the size of the read-out at that concentration, not a potency): 10%
Compound 3: middle estimate and measured number agree at the digits printed; the measured number falls inside the stated range.
By their numbers in this assay, from the lowest: compounds 1, 3 and 2 (each within the scatter of the next).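

Phenyl in place of methyl on the aromatic nitrogen gives a number 1.5 percentage points lower from compound 2 to compound 3 (within the scatter), the first direct reading of this change at this position, and the larger group of six carbon atoms leaves the read-out in this assay unresolved from that of the methyl compound. Compound 3 also provides a comparison at the carbonyl carbon: (2-aminoethyl)amino in place of methoxy, with phenyl on the nitrogen in both compounds, gives a number 0.9 percentage points higher from compound 1 to compound 3 (within the scatter), so neither change separates from the scatter. No measurement is available that could explain these results.

Going by these compounds, whether an ethyl or a benzyl on the aromatic nitrogen would move the number beyond the scatter remains open, as does the effect of a carboxylic acid or a longer chain in place of the (2-aminoethyl)amino group. On these data alone, the three compounds also show the read-out at a single concentration only, so their effect at any other concentration remains unknown.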